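The compounds below may be only part of what the source reports. "The series", "measured", "known", "first", "only" and "open" are said of these compounds alone.

Three compounds have been measured in a physicochemical assay for lipophilicity, at pH 7.4; on this read-out higher numbers stand for higher lipophilicity and lower numbers for lower lipophilicity:

compound 1, `COc1ccc(-c2cc(-c3cccc(S(C)(=O)=O)c3)cnc2N)cn1`: 2.3
compound 2, `COc1ccc(-c2cc(-c3ccc(S(=O)(=O)N(C)C)cc3)cnc2N)cn1`: 2.8
compound 3, `COc1ccc(-c2cc(-c3ccc(S(N)(=O)=O)cc3)cnc2N)cn1`: 1.8

Compound 3 stands lowest of the three in this assay; compound 1 is the nearer of the other two and compound 2 the furthest, both of them beyond the scatter. Within the data shown here, only one step between measured compounds changes a single place: a number 1.00 log units lower from compound 2 to compound 3 (beyond the scatter). Compound 4, `COc1ccc(-c2cc(-c3ccc(C(F)(F)F)cc3)cnc2N)cn1`, has not yet been measured. It differs from compound 3 in one place: trifluoromethyl in place of sulfamoyl on an aromatic carbon. Among the measured compounds shown here, no measured step covers this exact exchange. The step from compound 2 to compound 3 is the nearest guide: there a group bearing one hydrogen-bond donor replaced one bearing none on the sulfonyl sulfur, and the number fell. Compound 4 goes the other way and further, since the group that enters carries no hydrogen-bond donors and no acceptors, whereas the sulfamoyl that leaves has one donor and two acceptors. A rise in this assay is therefore expected, larger than the fall seen between compound 2 and compound 3. Compound 4 is estimated at 3.6, within a range from 3 to 4.2, which means an expected step of a number 1.80 log units higher from compound 3 to compound 4 (beyond the scatter).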

Compound 4, distribution coefficient: 4.2
Compound 4: middle estimate off by 0.60 log units, on the low side; low and high end bracket the measured number.
By their numbers in this assay, from the lowest: compound 3; then compound 1; then compound 2; then compound 4.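

In this assay, the earlier single-place step changed only what sits on the sulfonyl sulfur, whereas these steps replace the whole group on the aromatic carbon, para to a large group. Trifluoromethyl gives a number 2.40 log units higher from compound 3 to compound 4 (beyond the scatter) when it takes the place of sulfamoyl and a number 1.40 log units higher from compound 2 to compound 4 (beyond the scatter) when it takes the place of dimethylsulfamoyl, so this position tolerates a wide spread of numbers and the higher of the two sulfonyl-bearing compounds still lies well short of the trifluoromethyl one. Nothing available here explains why the number moves this far.

Among these compounds, only one group without sulfur stands at this place, so it remains open whether the size of these steps is particular to trifluoromethyl or would also appear with a nitrile, a chlorine, a methoxy group or a plain hydrogen. The compounds also leave open whether the same exchange would give a step of similar size on a core other than the shared one.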